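Working notes: microsomal clearance in the urea series, compound 3

A few compounds are considered here, and "the series" means these few. Any claim that something is new, unique, unknown or untested is made for them only; others in the source may bear on it.

Measured so far:
compound 1 `CCOc1cc(NC(=O)NCc2cc(C)c(-c3cn(C)nc3C(F)(F)F)nn2)cc(C#N)n1` — < 28.4 mL/min/kg
compound 2 `CCOc1cc(NC(=O)NCc2cc(C)c(-c3cn(C)nc3C(F)(F)F)nn2)cc(C)n1` — < 15 mL/min/kg

In an ADME assay on microsomes from liver (Homo sapiens) for metabolic stability, read by LC-MS, with a stated time of 4 h, tested at 1 uM (a higher number here means faster removal of the compound, a lower number slower removal), compound 1 gives < 28.4 mL/min/kg, which is a limit of the assay and not a number. In this assay compound 2 gives < 15 mL/min/kg, again a limit rather than a number. Within the data shown here, compound 2 therefore stands only at a limit, as does the one other value shown. Among the measured compounds shown here, the single step between measured compounds, a step that the two limits leave unreadable from compound 1 to compound 2, cannot be read in size, since both ends sit at limits: the limit of < 15 mL/min/kg in this assay, at which 1 of the 2 values shown sits, and (the limit of < 28.4 mL/min/kg in this assay, at which 1 of the 2 values shown sits).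

Compound 3 `CCOc1nc(Cl)cc(NC(=O)NCc2cc(C)c(-c3cn(C)nc3C(F)(F)F)nn2)c1C` is the next member and is not yet measured. It differs from compound 2 by 6-chloro-2-ethoxy-3-methylpyridin-4-yl in place of 2-ethoxy-6-methylpyridin-4-yl on an amide-type nitrogen. No measured step gives a readable size that bears on this change; the one step shown is unreadable. With both measured values at limits, no step beyond the usual scatter is expected from compound 2 to compound 3, which is what an at least 1.2-fold higher number from compound 2 to compound 3 (0.07 log units; that floor lies within the scatter) means here. Compound 3 is thus estimated at 18 mL/min/kg in this assay, with a range from 7 mL/min/kg to 45 mL/min/kg, and a fair chance that only a limit is reported.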

Compound 3, clearance: < 127 mL/min/kg
Compound 3: no number, only a limit; the forecaster's own chance of this, stated with the estimate: 50%; the middle value lies beyond the limit too.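

In this assay compound 3 gives < 127 mL/min/kg, a limit of the assay and not a number. Neither the step from compound 2 to compound 3 nor the step from compound 1 to compound 3 can be read in size. The compounds shown leave open how fast compound 1, compound 2 or compound 3 is actually removed, and whether 6-chloro-2-ethoxy-3-methylpyridin-4-yl in place of 2-ethoxy-6-methylpyridin-4-yl changes clearance at all.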